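Sulfonate anilides: amide chain replaced by an ethylurea

This account rests on a few compounds, and the source may have more. Where it says the series, first, only, none or still open, it means among the compounds named here.

Compound 3 `CC(C)c1ccccc1OS(=O)(=O)c1ccc(NC(=O)CCCCl)cc1` gives 6200 nM in a functional assay on HT-29 cells (Homo sapiens) for antiproliferative activity, read by sulforhodamine B assay, with a stated time of 48 h (a lower number here means a stronger inhibitor, a higher number a weaker inhibitor), the lowest of the three numbers shown, though the gap to compound 2 is within the scatter. Compound 2 `CCCCCC(=O)Nc1ccc(S(=O)(=O)Oc2ccccc2C(C)C)cc1` gives 6400 nM and compound 1 `CC(=O)Nc1ccc(S(=O)(=O)Oc2ccccc2C(C)C)cc1` gives 23000 nM; the three are linked by a 3.6-fold lower number from compound 1 to compound 2 (0.56 log units; beyond the scatter), a 3.7-fold lower number from compound 1 to compound 3 (0.57 log units; beyond the scatter) and a 1.0-fold lower number from compound 2 to compound 3 (0.01 log units; within the scatter). The change to compound 4 `CCNC(=O)Nc1ccc(S(=O)(=O)Oc2ccccc2C(C)C)cc1` is ethylamino in place of 3-chloropropyl on a carbonyl carbon. The first two steps show that enlarging the group on the carbonyl carbon from hydrogen lowers the number, while the third shows that exchanging chloro for ethyl within that chain changes nothing beyond the scatter. Compound 4 carries a group smaller than that of compound 3 but larger than that of compound 1, so a modest rise is expected, a 1.9-fold higher number from compound 3 to compound 4 (0.29 log units; within the scatter). Compound 4 is estimated at 12000 nM, range 5000 nM to 30000 nM.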

Compound 4, half-maximal inhibitory concentration: 1100 nM
For compound 4 the middle estimate is 11-fold (1.04 log units) above the measured one; measured number below the stated range.
By their numbers in this assay, from the lowest: compound 4; then compounds 3 and 2 (each within the scatter of the next); then compound 1.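

In this assay, ethylamino on a carbonyl carbon whose other neighbour is an amide-type nitrogen gives a 5.6-fold lower number from compound 3 to compound 4 (0.75 log units; beyond the scatter), a 5.8-fold lower number from compound 2 to compound 4 (0.76 log units; beyond the scatter) and a 21-fold lower number from compound 1 to compound 4 (1.32 log units; beyond the scatter). Earlier steps changed only the carbon chain on this carbonyl carbon, whereas ethylamino, though smaller than 3-chloropropyl by heavy atoms, gives a step beyond the scatter, so chain size alone does not order these compounds. No evidence on hand bears on this result.

Open, going by these compounds, is whether butylamino, a longer chain on the same nitrogen, continues the trend. Also open, on these data alone, is how ethoxy or phenylamino compares with ethylamino on this carbonyl carbon.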